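This account rests on a few compounds, and the source may have more. Where it says the series, first, only, none or still open, it means among the compounds named here.

Measured so far:

- compound 1, `CCN(Cc1ccccc1)C(=O)C1CCN(S(=O)(=O)c2cccc3c2OCCO3)CC1`: 53% in a functional assay on CHO cells for positive allosteric modulation of muscarinic acetylcholine receptor M5 (Homo sapiens), read by calcium flux; a higher number here means a larger maximal response, a lower number a smaller maximal response
- compound 2, `CCN(Cc1ccccc1)C(=O)C1CCN(S(=O)(=O)c2ccc3[nH]ncc3c2)CC1`: 86%
- compound 3, `C=CCN(Cc1ccccc1C(F)(F)F)C(=O)C1CCN(S(=O)(=O)c2ccc3[nH]ncc3c2)CC1`: 79%

Compound 3 stands second highest of the three. Compound 2 is its nearest neighbour, within the scatter, while compound 1 is furthest, beyond it. Within the data shown here, the one clean step recorded, a number 33 percentage points higher from compound 1 to compound 2 (beyond the scatter), concerns the sulfonyl aryl, which compound 3 and compound 4 share unchanged. Compound 4, `O=C(C1CCN(S(=O)(=O)c2ccc3[nH]ncc3c2)CC1)N(Cc1ccccc1C(F)(F)F)C1CCC1`, differs from compound 3 only at the amide-type nitrogen: cyclobutyl in place of allyl on an amide-type nitrogen. Among the measured compounds shown here, no measured step touches that nitrogen; compound 2 and compound 3 differ there and elsewhere at once, and their values sit within the scatter. For compound 4 a step of a number 3 percentage points lower from compound 3 to compound 4 (within the scatter) is expected, none beyond the scatter. Compound 4 is thus estimated at 76%, between 56% and 94%.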

Compound 4, largest response reached (reported as percent of maximum), in percent of the reference or control that the assay uses: 84%
Compound 4: the middle estimate sits 8 percentage points below what was measured, and the stated range covers the measured number.
By their numbers in this assay, from the lowest: compound 1; then compounds 3, 4 and 2 (each within the scatter of the next).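

In this assay, cyclobutyl in place of allyl on an amide-type nitrogen gives a number 5 percentage points higher from compound 3 to compound 4 (within the scatter), the first step read at this nitrogen alone. With the trifluoromethyl benzyl group and the sulfonyl aryl held fixed, the double bond of allyl can give way to a four-membered carbon ring with no change beyond the scatter. Nothing at hand bears on the reason for this result.

Still open, on these data alone, is whether a longer chain or a carbon group carrying an amine or a carboxylic acid on this nitrogen would hold the response. Also open, as far as these compounds go, is whether cyclobutyl behaves alike with the sulfonyl aryl of compound 1.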